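The source may hold more compounds than are shown below. What is called first, only, known or untested is meant among the compounds shown, and "the series" means these compounds.

Series notes. Compound 1 `CC(C)C(=O)N1CCC[C@H]1C(=O)N1CCC(NS(=O)(=O)c2cc(S(=O)(=O)c3ccccc3)ccc2C(F)(F)F)CC1`, compound 2 `CC(C)(C)C(=O)N1CCC[C@H]1C(=O)N1CCC(NS(=O)(=O)c2cc(S(=O)(=O)c3ccccc3)ccc2C(F)(F)F)CC1` and compound 3 `CN(C)CC(=O)N1CCC[C@H]1C(=O)N1CCC(NS(=O)(=O)c2cc(S(=O)(=O)c3ccccc3)ccc2C(F)(F)F)CC1` share one core and differ only in the group on the carbonyl carbon that is bound to the amide-type nitrogen in a ring. In an assay on isolated protein for binding affinity to secreted frizzled-related protein 1 (Homo sapiens), read by fluorescence (a lower number here means a stronger inhibitor, a higher number a weaker inhibitor), compound 1 gives 40 nM, compound 2 gives 40 nM and compound 3 gives 90 nM. The step of no change at the digits printed from compound 1 to compound 2 (within the scatter) shows that a methyl added on the saturated chain carbon is neutral. The steps of a 2.3-fold higher number from compound 1 to compound 3 (0.35 log units; beyond the scatter) and a 2.3-fold higher number from compound 2 to compound 3 (0.35 log units; beyond the scatter) place compound 3 at the highest number of the three, each of its neighbours a modest distance away.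

Compound 4 `CN(C)C(=O)N1CCC[C@H]1C(=O)N1CCC(NS(=O)(=O)c2cc(S(=O)(=O)c3ccccc3)ccc2C(F)(F)F)CC1` is the next member, differing from compound 3 by dimethylamino in place of (dimethylamino)methyl on a carbonyl carbon. Of the measured steps, those ending at compound 3 bear most directly on it, since both exchange the group on the same carbonyl carbon and both were modest; the step from compound 1 to compound 2 shows the smaller alteration in this region to be without effect. A change of at most modest size in this assay is therefore expected, with no clear direction, so that the estimated step of no change at the digits printed from compound 3 to compound 4 (within the scatter) is small. Compound 4 is expected to give about 90 nM, with a range of 40 nM to 200 nM.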

Compound 4, half-maximal inhibitory concentration: 30 nM
Beside the measured number, compound 4's estimate is 3.0-fold (0.48 log units) above it, and the stated range ends above it.
By their numbers in this assay, from the lowest: compounds 4, 1 and 2 (each within the scatter of the next); then compound 3.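

In this assay, shortening the group on this carbonyl carbon by removing the carbon that separates it from the dimethylamino nitrogen gives a clear step (a 3.0-fold lower number from compound 3 to compound 4 (0.48 log units; beyond the scatter)), so carrying a dimethylamino nitrogen in this group does not by itself go with the higher number of compound 3. The steps (a 1.3-fold lower number from compound 1 to compound 4 (0.12 log units; within the scatter)) and (a 1.3-fold lower number from compound 2 to compound 4 (0.12 log units; within the scatter)) show that dimethylamino on this carbonyl carbon, whose other neighbour is the amide-type nitrogen in a ring, matches the isopropyl and tert-butyl groups within the scatter, so among these four compounds only compound 3 goes against a flat reading of this position. No measurement available here explains why the (dimethylamino)methyl group stands apart from the other three groups.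

On these data alone, it remains open whether the higher number of compound 3 extends to other groups with a carbon between the carbonyl carbon and the nitrogen, such as (methylamino)methyl or a longer chain such as (dimethylamino)ethyl. As far as these compounds go, how a carboxylic acid or a primary amine carried on this carbonyl carbon would read in this assay also remains open.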